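Swapping the aryl group on the benzylidene arm of compound 1

The source may hold more compounds than are shown below. What is called first, only, known or untested is meant among the compounds shown, and "the series" means these compounds.

Measured compounds:
- compound 1, `O=C1C(=Cc2ccc(Cl)cc2)C(=O)N(c2ccc(Cl)cc2)N1c1ccc(Cl)cc1`: 32600 nM
- compound 2, `O=C1C(=Cc2ccc(Br)cc2)C(=O)N(c2ccc(Cl)cc2)N1c1ccc(Cl)cc1`: 16900 nM

Both values come from a functional assay on MGC-803 cells (Homo sapiens) for cytotoxicity, read by MTT assay, with a stated time of 72 h; on this read-out higher numbers stand for weaker inhibition and lower numbers for stronger inhibition. Compound 1 gives the highest of the two numbers measured in this assay; its nearest neighbour is compound 2, and the step of a 1.9-fold lower number from compound 1 to compound 2 (0.29 log units; within the scatter) lies within the scatter, so the two compounds cannot be told apart on this read-out.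

Compound 3, `O=C1C(=Cc2ccc(F)cc2F)C(=O)N(c2ccc(Cl)cc2)N1c1ccc(Cl)cc1`, has not yet been measured in this assay. It differs from compound 1 in one place: 2,4-difluorophenyl in place of 4-chlorophenyl on a double-bonded chain carbon bound to a double-bonded ring carbon. Among the compounds with values here, the only measured step, a 1.9-fold lower number from compound 1 to compound 2 (0.29 log units; within the scatter), changes the same aryl group at the same place, but by a different exchange, and it stayed within the scatter. Nothing measured here shows what replacing the whole 4-chlorophenyl with 2,4-difluorophenyl does, so the step of a 1.1-fold lower number from compound 1 to compound 3 (0.04 log units; within the scatter) is expected to be small and to stay within the scatter. Compound 3 is therefore estimated at 30000 nM, with a range from 12000 nM to 75000 nM in this assay.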

Compound 3, half-maximal inhibitory concentration: 35700 nM
For compound 3 the middle estimate is 1.2-fold (0.08 log units) below the measured one, within the range that was stated.
By their numbers in this assay, from the lowest: compounds 2, 1 and 3 (each within the scatter of the next, the first and the last beyond it).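

In this assay the step of a 1.1-fold higher number from compound 1 to compound 3 (0.04 log units; within the scatter) shows that this position tolerates more than an exchange of one halogen for another: the whole 4-chlorophenyl can give way to 2,4-difluorophenyl on this double-bonded chain carbon with no change that can be told apart. Within the data shown here, the step of a 2.1-fold higher number from compound 2 to compound 3 (0.32 log units; beyond the scatter) is the first at this place to pass the scatter, and it does so only modestly, so the set now holds one pair that can be ordered, while each of its other two pairs remains unresolved. No measured evidence is available to explain these results.

All three groups at this place are phenyl rings carrying halogens, so the position has been probed only within that one narrow family. Going by these compounds, what a phenyl ring carrying an amine or a carboxylic acid would do here remains open, as does the effect of a methoxy group or of a longer chain in place of the aryl group.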